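Changing the sulfonyl aryl group of compound 3

The source may report more compounds than this note shows. Statements on the series, on what has been measured and on what is new or still open speak of the compounds shown alone.

Of the compounds shown here, three sharing one core have been measured in a functional assay on DU-145 cells (Homo sapiens) for inhibition, read by trypan blue exclusion, with a stated time of 72 h; on this read-out lower numbers stand for stronger inhibition and higher numbers for weaker inhibition. Compound 1 `Cn1c(=O)c(S(=O)(=O)c2ccc(C(=O)O)cc2)cc2cnc(Nc3ccc4[nH]ccc4c3)nc21` gives 10000 nM, compound 2 `Cn1c(=O)c(C(=O)Nc2ccc(F)cc2F)cc2cnc(Nc3ccc4[nH]ccc4c3)nc21` gives 5000 nM, and compound 3 `Cc1ccc(S(=O)(=O)c2cc3cnc(Nc4ccc5[nH]ccc5c4)nc3n(C)c2=O)cc1` gives 750 nM, the lowest number of the three.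

The next compound, compound 4 `Cn1c(=O)c(S(=O)(=O)c2ccc(N)cc2F)cc2cnc(Nc3ccc4[nH]ccc4c3)nc21`, has 4-amino-2-fluorophenyl in place of 4-methylphenyl on a sulfonyl sulfur. Among the compounds with values here, two measured steps bear on this change. Methyl in place of carboxy on an aromatic carbon, within the same aryl group, gave a large step, a 13-fold lower number from compound 1 to compound 3 (1.12 log units; beyond the scatter). Replacing (2,4-difluorophenyl)carbamoyl with (4-methylphenyl)sulfonyl gave a modest one, a 6.7-fold lower number from compound 2 to compound 3 (0.82 log units; beyond the scatter). Both show that changes in this part of the molecule can move the number beyond the scatter, but neither tests an amino group, so the direction remains uncertain.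

A small shift towards a lower number is expected in this assay, and the estimated step is a 1.5-fold lower number from compound 3 to compound 4 (0.18 log units; within the scatter). For compound 4 the expected value is 500 nM, with an estimated range from 100 nM to 2500 nM.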

Compound 4, half-maximal inhibitory concentration: 8000 nM
Compound 4: the middle estimate sits 16-fold (1.20 log units) below what was measured; the measured number lies above the stated range.
By their numbers in this assay, from the lowest: compound 3; then compounds 2, 4 and 1 (each within the scatter of the next).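

In this assay, within the data shown here, replacing 4-methylphenyl with 4-amino-2-fluorophenyl on the sulfonyl sulfur gives an 11-fold higher number from compound 3 to compound 4 (1.03 log units; beyond the scatter), so the carboxy group of compound 1 is no longer the only change to this aryl group seen to go with a much weaker result. The other two comparisons, a 1.3-fold lower number from compound 1 to compound 4 (0.10 log units; within the scatter) and a 1.6-fold higher number from compound 2 to compound 4 (0.20 log units; within the scatter), both lie within the scatter, which leaves compound 3 as the only one of the four clearly apart from the rest, with the strongest inhibition. No measured evidence is available to explain the loss.

The amino group and the fluorine enter together, so the compounds shown cannot tell which of them goes with the step. A phenyl group carrying only one of the two would separate them, and an ethyl group in place of the methyl of compound 3 would test how much room this position allows.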